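This account rests on a few compounds, and the source may have more. Where it says the series, first, only, none or still open, it means among the compounds named here.

Compound 1 `CCOCC1CN(c2ccccc2)NC1=O` gives 280 nM in an assay on isolated protein for inhibition of Polyunsaturated fatty acid 5-lipoxygenase (Rattus norvegicus); on this read-out lower numbers stand for stronger inhibition and higher numbers for weaker inhibition. Compound 2 `CC(C)(O)C1CN(c2ccccc2)NC1=O` gives only a limit of this assay, > 1000 nM.

Compound 2 thus sits at the weak end of what has been measured, its value being (the limit of > 1000 nM in this assay, at which 1 of the 2 values shown sits). The untested compound 3 `O=C1NN(c2ccccc2)CC1Cc1cccs1` differs from compound 2 by (thiophen-2-yl)methyl in place of 1-hydroxy-1-methylethyl on a saturated ring carbon. Among the measured compounds shown here, one measured step bears on this change: an at least 3.5-fold higher number from compound 1 to compound 2 (0.55 log units; beyond the scatter), a loss that accompanied the entry of the 1-hydroxy-1-methylethyl group in place of ethoxymethyl. Because that step an at least 3.5-fold higher number from compound 1 to compound 2 (0.55 log units; beyond the scatter) tracked the arrival of the group which compound 3 now removes, the number for compound 3 is expected to fall back toward the level of compound 1 rather than stay at the limit. Compound 3 is estimated at 350 nM, with a range from 120 nM to 1000 nM. This corresponds to an expected at least 2.8-fold lower number from compound 2 to compound 3 (0.45 log units; beyond the scatter), in the direction of stronger inhibition.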

Compound 3, half-maximal inhibitory concentration: 140 nM
For compound 3 the middle estimate is 2.5-fold (0.40 log units) above the measured one, within the range that was stated.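

In this assay, the loss seen with compound 2 does not extend to every replacement of ethoxymethyl at this saturated ring carbon: (thiophen-2-yl)methyl gives an at least 7.1-fold lower number from compound 2 to compound 3 (0.85 log units; beyond the scatter). Compound 2 has the value > 1000 nM, which is a limit of the assay and not a number, so this step has no exact size. The thiophene-bearing group also gives a 2.0-fold lower number from compound 1 to compound 3 (0.30 log units; within the scatter), so this position accepts a five-membered aromatic ring as well as the open ethoxymethyl chain, and the two cannot be separated here.

An isopropyl group would help show whether the hydroxyl or the branching of 1-hydroxy-1-methylethyl goes with the weak result in compound 2. Benzyl or furan-2-ylmethyl would test whether the thiophene ring itself matters, while a carboxylic acid or an amine on the chain remains unexplored.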